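Lengthening an ether chain from compound 3 to compound 4

The compounds below may be only part of what the source reports. "The series", "measured", "known", "first", "only" and "open" are said of these compounds alone.

- compound 1 `CNc1nc(N)nc2c1ncn2/C=C1/CC1(CO)CO`: 67000 nM
- compound 2 `C=CCOc1nc(N)nc2c1ncn2/C=C1/CC1(CO)CO`: > 20000 nM (a limit)
- compound 3 `COCCOc1nc(N)nc2c1ncn2/C=C1/CC1(CO)CO`: > 20000 nM (a limit)

In an ADME assay on BCBL1 cells (Homo sapiens) for cytotoxicity, with a stated time of 7 days (on this read-out higher numbers stand for lower toxicity in this test and lower numbers for higher toxicity in this test), compound 3 has no number, only a limit, > 20000 nM. The next structure, compound 4 `CCCCCCCCOc1nc(N)nc2c1ncn2/C=C1/CC1(CO)CO`, carries hexyl in place of methoxy on a saturated chain carbon, two bonds along the chain from an oxygen on an aromatic ring. This turns 2-methoxyethoxy into octyloxy. The closest measured change is a step that the two limits leave unreadable from compound 2 to compound 3. The other one reaching compound 3 is a step that the limit leaves unreadable from compound 1 to compound 3. Neither offers a size to carry over, so no step beyond the usual scatter is expected in this assay, and no direction can be favoured. The expected change is a step that the limit leaves unreadable from compound 3 to compound 4. The estimate for compound 4 is 25000 nM, with an expected range from 7000 nM to 70000 nM.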

Compound 4, half-maximal cytotoxic concentration: > 20000 nM
Compound 4: no number, only a limit; the forecaster's own chance of this, stated with the estimate: 50%; the middle value does not contradict the limit.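

Compound 4 shows only a limit, > 20000 nM, in this assay, so no step linking it to compound 1, compound 2 or compound 3 can be read: the limit of > 20000 nM in this assay, at which 3 of the 4 values shown sit.

The compounds shown leave open whether the ether chains of compound 2, compound 3 and compound 4 differ at all in toxicity in this test.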